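Methyl in Place of Bromo on the Triazole Aryl Ring

The compounds below may be only part of what the source reports. "The series", "measured", "known", "first", "only" and "open" are said of these compounds alone.

Compound 1 `O=C1O/C(=C\Cn2cc(-c3ccc(Br)cc3)nn2)C(OCc2ccccc2)=C1OCc1ccccc1` was examined in a functional assay on HeLa cells (Homo sapiens) for antiproliferative activity, read by MTT assay, with a stated time of 72 h (on this read-out lower numbers stand for stronger inhibition and higher numbers for weaker inhibition), where compound 1 gives 24300 nM. Among the three numbers in hand, this stands second highest. Compound 3 `O=C1O[C@H]([C@@H](O)Cn2cc(-c3cc(C(F)(F)F)cc(C(F)(F)F)c3)nn2)C(OCc2ccccc2)=C1OCc1ccccc1` is the nearest; in this assay compound 3 gives 35500 nM, a difference from compound 1 that lies within the scatter of repeated measurements. Compound 2 `O=C1O[C@H]([C@@H](O)Cn2cc(-c3ccc(Br)cc3)nn2)C(OCc2ccccc2)=C1OCc1ccccc1` is the furthest; in this assay compound 2 gives 3910 nM, a lower number than that of compound 1 by a margin beyond the scatter. For the measured compounds named here, both compound 2 and compound 3 differ from compound 1 in more than one place at once, so no single-site step between measured compounds is available for comparison.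

Compound 4 `Cc1ccc(-c2cn(C/C=C3\OC(=O)C(OCc4ccccc4)=C3OCc3ccccc3)nn2)cc1` is the untested counterpart of compound 1. The change is methyl in place of bromo on an aromatic carbon. Going by the values given here, no measured pair shows this exchange, and the direction of its effect in this assay is therefore not established by the data. The expectation is a 1.2-fold higher number from compound 1 to compound 4 (0.09 log units; within the scatter), a step small enough to remain within the scatter. Compound 4 is estimated at 30000 nM, with a range from 10000 nM to 90000 nM.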

Compound 4, half-maximal inhibitory concentration: 7480 nM
Compound 4: middle estimate off by 4.0-fold (0.60 log units), on the high side; the measured number lies below the stated range.
By their numbers in this assay, from the lowest: compounds 2 and 4 (each within the scatter of the next); then compounds 1 and 3 (each within the scatter of the next).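

For the compounds shown here, the exchange of 4-bromophenyl for 4-methylphenyl provides the only single-site step at hand: in this assay it reads a 3.2-fold lower number from compound 1 to compound 4 (0.51 log units; beyond the scatter) and shows that the group on this aromatic carbon, para to a large group, can shift the number on the core of compound 1 by more than the usual scatter. Bromo and methyl count alike in heavy atoms, hydrogen-bond donors, hydrogen-bond acceptors, rings and net charge, so none of these counted features separates compound 1 from compound 4. Nothing in the information at hand bears on what lies behind this step.

On these data alone, whether the same exchange would move the number in the same direction on the core of compound 2, which also carries the 4-bromophenyl group, remains open. As far as these compounds go, with a single step in hand, it is also open how other groups at this aromatic carbon would read in this assay, among them chloro, methoxy, an amine, a carboxylic acid or a longer chain such as ethyl, so no trend across substituents can yet be drawn.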